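Three inactive limits and a sulfonyl replacing an ether

The compounds below may be only part of what the source reports. "The series", "measured", "known", "first", "only" and "open" are said of these compounds alone.

Measured compounds in an ADME assay on Raji cells (Homo sapiens) for cytotoxicity, read by CellTiter-Glo and resazurin assay, with a stated time of 72 h; a lower number here means that less compound is needed, a higher number that more compound is needed for the effect:
- compound 1 `CC(C)COc1cccc(-c2ccc(C(=O)N(Cc3cccc(OCCCCCC(=O)O)c3)C(C)C)cc2)c1` gives a limit, > 26000 nM
- compound 2 `COc1cccc(-c2ccc(C(=O)N(Cc3cccc(OCCCCCC(=O)O)c3)C(C)C)cc2)c1` gives a limit, > 20900 nM
- compound 3 `CCOC(=O)CCCCCOc1cccc(CN(C(=O)c2ccc(-c3cccc(OCC(C)C)c3)cc2)C(C)C)c1` gives a limit, > 26000 nM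

All three compounds share one core and each returned only a limit, so none of them shows a readable number. Compound 3 sits at the limit of > 26000 nM in this assay, at which 2 of the 3 values shown sit, together with one other compound, while the remaining compound sits at the limit of > 20900 nM in this assay, at which 1 of the 3 values shown sits. The two measured steps, a step that the two limits leave unreadable from compound 1 to compound 2 and a step that the two limits leave unreadable from compound 1 to compound 3, are therefore unreadable: a limit on each side gives no size and no direction.

Compound 4 `CCOC(=O)CCCCCOc1cccc(CN(C(=O)c2ccc(-c3cccc(S(C)(=O)=O)c3)cc2)C(C)C)c1` carries the change (methylsulfonyl in place of isobutoxy on an aromatic carbon). Among the compounds with values here, no measured step involves a methylsulfonyl group, and the steps that do exist are unreadable, so the only guide is that every compound of this series so far stopped at a limit. Compound 4 is therefore expected to give 26000 nM, within 8000 nM to 80000 nM, most likely again as a limit rather than a number. The expected step of a number no higher from compound 3 to compound 4 (the limit leaves the size open) is estimated to be none beyond the scatter.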

Compound 4, half-maximal effective concentration: > 26000 nM
Compound 4: only a limit was reported (the forecaster's own chance of this, stated with the estimate: 75%); the middle value lies on the limit itself.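

In this assay, within the data shown here, compound 3 and compound 4 both return only limits, so the swap of isobutoxy for methylsulfonyl gives no step of readable size or direction. The compounds shown leave open whether this assay can give a readable number for any compound with this shared core.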